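Dropping a methoxy group: an expected small change

The source may report more compounds than this note shows. Statements on the series, on what has been measured and on what is new or still open speak of the compounds shown alone.

Compound 2 `COc1ccc(/C=C2\CCN=C2c2cccnc2)c(OC)c1` and compound 1 `COc1ccc(/C=C2\CCN=C2c2cccnc2)c(O)c1` share one core and differ only at one oxygen on an aromatic ring, which carries a methyl in compound 2 and a hydrogen in compound 1. In an assay for displacement of a labelled ligand from Nicotinic acetylcholine receptor alpha8 subunit (Periplaneta americana), read by scintillation counting, with a stated time of 2 h, at 24 degrees C (a higher number here means a weaker inhibitor, a lower number a stronger inhibitor), compound 1 gives 3890 nM, and compound 2 gives 4550 nM. Among the measured compounds shown here, compound 2 holds the higher of the two numbers, but the only measured step, a 1.2-fold higher number from compound 1 to compound 2 (0.07 log units; within the scatter), lies within the scatter, so the two compounds cannot be told apart on this evidence.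

Compound 3 `COc1ccc(/C=C2\CCN=C2c2cccnc2)cc1` follows from compound 2 by the change hydrogen in place of methoxy on an aromatic carbon. For the measured compounds named here, no measured step removes this group outright; the one step that touches the same group, a 1.2-fold higher number from compound 1 to compound 2 (0.07 log units; within the scatter), altered only what sits on its oxygen, and it stayed within the scatter. That is thin ground, and it points to no large movement in this assay in either direction. The estimate for compound 3 is therefore 5500 nM, with a range from 2000 nM to 15000 nM, an expected step of a 1.2-fold higher number from compound 2 to compound 3 (0.08 log units; within the scatter) that is not beyond the scatter.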

Compound 3, half-maximal inhibitory concentration: > 10000 nM
Compound 3: a limit, no number; the forecaster's own chance of this, stated with the estimate: 5%; middle value at least 1.8-fold (0.25 log units) away from the limit.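

Compound 3 gives a limit of the assay and not a number: the limit of > 10000 nM in this assay, at which 1 of the 3 values shown sits.

Even so, both steps to it can be read: an at least 2.1-fold higher number from compound 2 to compound 3 (0.34 log units; beyond the scatter), and an at least 2.5-fold higher number from compound 1 to compound 3 (0.41 log units; beyond the scatter), each beyond the scatter in this assay. Compound 1 and compound 2, which carry hydroxy and methoxy at this place, ortho to a large group, cannot be told apart, so the earlier compounds showed only that the hydrogen or methyl on the oxygen makes no clear difference; compound 3 adds that leaving out the whole group, oxygen included, does, and among these three compounds the one with bare hydrogen there holds the highest reading, which means the weakest binding of the set.

Among the compounds shown here, how much weaker compound 3 really is stays open, since a limit sets only one side of the step. Also open, from the compounds shown here alone, is whether another group at this place, such as an amine, a fluorine atom or a longer chain like ethoxy, would behave like hydroxy and methoxy or like hydrogen.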